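Azido replaced by methoxymethyl on the fluorinated aminochromone core

The source may report more compounds than this note shows. Statements on the series, on what has been measured and on what is new or still open speak of the compounds shown alone.

Measured so far in a functional assay on HeLa cells (Homo sapiens) for cytotoxicity, read by neutral red uptake, with a stated time of 3 days; a higher number here means a weaker inhibitor, a lower number a stronger inhibitor:
- compound 1 `Nc1ccc(-c2cc(=O)c3c(N)c(F)c(Br)c(F)c3o2)cc1F`: > 100000 nM, a limit of this assay
- compound 2 `[N-]=[N+]=Nc1c(F)c(N)c2c(=O)cc(-c3ccc(N)c(F)c3)oc2c1F`: 1200 nM
- compound 3 `CCCCCCCCCCCCCCCCCC(=O)OCc1c(F)c(N)c2c(=O)cc(-c3ccc(N)c(F)c3)oc2c1F`: > 100000 nM, a limit of this assay

Within the data shown here, compound 2 holds the only number in this assay; the other two values are limits, as the limit of > 100000 nM in this assay, at which 2 of the 3 values shown sit, records. Among the measured compounds shown here, the one measured single-point step is an at least 83-fold lower number from compound 1 to compound 2 (1.92 log units; beyond the scatter), so on this core the substituent at this position decides whether a number is reached at all. Compound 3, carrying a long ester chain at the same position, also returns only a limit.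

Compound 4 `COCc1c(F)c(N)c2c(=O)cc(-c3ccc(N)c(F)c3)oc2c1F` differs from compound 2 as follows: methoxymethyl in place of azido on an aromatic carbon. For the measured compounds named here, no measured step bears directly on this exchange. Going by the values given here, the only guide is that compound 2 alone, with azido, gives a number, while the bromo and ester analogues do not, and the large size of an at least 83-fold lower number from compound 1 to compound 2 (1.92 log units; beyond the scatter) marks azido as the decisive group. A step toward weaker inhibition is therefore expected, of roughly a 17-fold higher number from compound 2 to compound 4 (1.22 log units; beyond the scatter), with a real chance that only a limit is returned. Compound 4 is expected at 20000 nM, between 3000 nM and 100000 nM.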

Compound 4, half-maximal inhibitory concentration: > 100000 nM
Compound 4: no number, only a limit; the forecaster's own chance of this, stated with the estimate: 35%; middle value at least 5.0-fold (0.69 log units) away from the limit.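

In this assay, methoxymethyl in place of azido gives an at least 83-fold higher number from compound 2 to compound 4 (1.92 log units; beyond the scatter). The two groups match in heavy-atom count and in hydrogen-bond donor and acceptor counts, so these counts do not separate a compound with a number from one without, which the bromo and ester analogues could not show. Of the four groups shown at this position on the shared core, only azido gives a number, and compounds 1, 3 and 4 all end at the same limit: the limit of > 100000 nM in this assay, at which 3 of the 4 values shown sit.

The step between compound 1 and compound 4 cannot be read, as both values are limits. Going by these compounds, whether a small group such as an amine, a nitrile or a carboxylic acid at this position also returns a number remains open, so it is not yet known whether azido is unique here.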